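Cytotoxicity step from compound 3 to compound 4

This account rests on a few compounds, and the source may have more. Where it says the series, first, only, none or still open, it means among the compounds named here.

In a toxicity assay on HEK-293T cells (Homo sapiens) for cytotoxicity, read by MTT assay, with a stated time of 72 h (a lower number here means a stronger inhibitor, a higher number a weaker inhibitor), compound 1 (`CC1(C)OC[C@H](Cn2cc(Cn3c4c(c5ccccc53)C(=O)c3c[n+]([O-])c5ccccc5c3C4=O)nn2)O1`) gives 100 nM and compound 2 (`CN1CCN(CCCn2c3c(c4ccccc42)C(=O)c2c[n+]([O-])c4ccccc4c2C3=O)CC1`) gives 170 nM while compound 3 (`O=C1c2c[n+]([O-])c3ccccc3c2C(=O)c2c1c1ccccc1n2Cc1cn([C@@H]2O[C@H](CO)[C@@H](O)[C@H](O)[C@H]2O)nn1`) gives 940 nM as the highest of the three numbers. Compound 4 (`O=C1c2c[n+]([O-])c3ccccc3c2C(=O)c2c1c1ccccc1n2Cc1cn(C[C@@H](O)CO)nn1`) awaits measurement and differs from compound 3 by 2,3-dihydroxypropyl in place of 3,4,5-trihydroxy-6-(hydroxymethyl)oxan-2-yl on an aromatic nitrogen. Among the measured compounds shown here, the one measured step bearing on this is a 9.4-fold higher number from compound 1 to compound 3 (0.97 log units; beyond the scatter) and it is modest but beyond the scatter, with (2,2-dimethyl-1,3-dioxolan-4-yl)methyl giving way to the same oxan-2-yl group. Only part of that step is expected to reverse. The estimated step is a 3.1-fold lower number from compound 3 to compound 4 (0.50 log units; beyond the scatter) in this assay and points to a lower number. Compound 4 is expected at 300 nM with an estimated range of 110 nM to 800 nM for now.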

Compound 4, half-maximal inhibitory concentration: 2030 nM
Beside the measured number, compound 4's estimate is 6.8-fold (0.83 log units) below it, outside the stated range (above it).
By their numbers in this assay, from the lowest: compounds 1 and 2 (each within the scatter of the next); then compound 3; then compound 4.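

In this assay 2,3-dihydroxypropyl in place of 3,4,5-trihydroxy-6-(hydroxymethyl)oxan-2-yl on the aromatic nitrogen gives a 2.2-fold higher number from compound 3 to compound 4 (0.33 log units; beyond the scatter) and so the number does not fall when the ring leaves. Opening 2,2-dimethyl-1,3-dioxolan-4-yl to 1,2-dihydroxyethyl gives a 20-fold higher number from compound 1 to compound 4 (1.31 log units; beyond the scatter) and the change from the 2-(4-methylpiperazin-1-yl)ethyl chain gives a 12-fold higher number from compound 2 to compound 4 (1.08 log units; beyond the scatter) as the other large step. No available evidence bears on why these steps occur.

Still open, on these data alone, is how a primary amine or a carboxylic acid on that aromatic nitrogen would read in this assay against compound 4.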